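Discodermolide-type chain: terminal aryl swap, chloro to dihydroxy

This account rests on a few compounds, and the source may have more. Where it says the series, first, only, none or still open, it means among the compounds named here.

Measured so far:
- compound 1, `C=C/C=C\[C@H](C)[C@H](OC(N)=O)[C@@H](C)[C@H](O)[C@@H](C)C/C(C)=C\[C@H](C)[C@@H](O)[C@@H](C)/C=C\CCc1ccc(Oc2ccccc2)cc1`, in a functional assay on SK-OV-3 cells (Homo sapiens) for cytotoxicity (a lower number here means a stronger inhibitor, a higher number a weaker inhibitor), gives 10000 nM
- compound 2, `C=C/C=C\[C@H](C)[C@H](OC(N)=O)[C@@H](C)[C@H](O)[C@@H](C)C/C(C)=C\[C@H](C)[C@@H](O)[C@@H](C)/C=C\CCc1cccc(Cl)c1`, in this assay gives 380 nM

Compound 2 carries the lowest of the two numbers in this assay; compound 1 sits at a clearly higher number, and the gap between the two lies beyond the usual scatter. For the measured compounds named here, the two compounds differ only in the aryl group at the end of the chain, but no single-point step between them has been worked out, so the pair is taken only as the range the series has covered so far.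

Compound 3, `C=C/C=C\[C@H](C)[C@H](OC(N)=O)[C@@H](C)[C@H](O)[C@@H](C)C/C(C)=C\[C@H](C)[C@@H](O)[C@@H](C)/C=C\CCc1cc(O)cc(O)c1`, is the next member. Relative to compound 2 the change is 3,5-dihydroxyphenyl in place of 3-chlorophenyl on a saturated chain carbon, two bonds along the chain from a double-bonded chain carbon. Going by the values given here, nothing among the measured compounds shows how this aryl change plays out in this assay. The expectation is a moderate step upward in the number from compound 2 to compound 3, a 5.3-fold higher number from compound 2 to compound 3 (0.72 log units; beyond the scatter), with wide uncertainty. For compound 3 the estimate in this assay is 2000 nM, with a range from 400 nM to 10000 nM.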

Compound 3, half-maximal inhibitory concentration: 40 nM
Estimate against measurement, compound 3: 50-fold (1.70 log units) above; measured number below the stated range.
By their numbers in this assay, from the lowest: compound 3; then compound 2; then compound 1.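

In this assay, the aryl group on a saturated chain carbon, two bonds along the chain from a double-bonded chain carbon, proves sensitive to its substituents: 3,5-dihydroxyphenyl in place of 3-chlorophenyl gives a 9.5-fold lower number from compound 2 to compound 3 (0.98 log units; beyond the scatter) and takes the series to 40 nM for compound 3. The result also shows that this position accepts an aryl group with 2 hydrogen-bond donors and 2 hydrogen-bond acceptors, where 3-chlorophenyl has 0 of each, and that the number still falls rather than rises. No measurement at hand accounts for the size or the direction of this step, so it stands as an observation only.

The compounds shown leave open whether both hydroxyl groups are needed for the step or a single hydroxyl group on the ring would give the same number. They also leave open whether methoxy groups, amines or a carboxylic acid could stand in for the hydroxyl groups, and how a longer chain carrying the 3,5-dihydroxyphenyl group would read in this assay.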